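A few compounds are considered here, and "the series" means these few. Any claim that something is new, unique, unknown or untested is made for them only; others in the source may bear on it.

Working notes on the series.

Three compounds have numbers in an assay on IMR-32 cells for displacement of a labelled ligand from corticotropin-releasing factor receptor 1 (Homo sapiens), read by scintillation counting, with a stated time of 2 h; a lower number here means a stronger inhibitor, a higher number a weaker inhibitor. Compound 1, `CCCN(CC1CC1)c1nc(CC)c(-c2ccc(Cl)cc2Cl)nc1CC`, gives 19.2 nM. Compound 2, `CCOc1ccc(-c2nc(OC)c(NC(CC)CC)nc2C)c(Cl)c1`, gives 5.9 nM, and compound 3, `CCc1nc(NC(CC)CC)c(Cl)nc1-c1ccc(Cl)cc1Cl`, gives 71 nM. Compound 1 thus stands second highest of the three, with compound 2 the nearer neighbour at a lower number and compound 3 the further one at a higher number; both gaps lie beyond the usual scatter. Within the data shown here, compound 2 and compound 3 differ from compound 1 in several places at once, so no single step between measured compounds is available.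

Compound 4, `CCCN(CCN(C)C)c1nc(CC)c(-c2ccc(Cl)cc2Cl)nc1CC`, keeps the core of compound 1 and differs from it in one place: (dimethylamino)methyl in place of cyclopropyl on a saturated chain carbon bound to a nitrogen on an aromatic ring. Among the measured compounds shown here, no measured pair shows this change, so the expectation rests on the change itself. A modest rise in the number is expected, toward weaker inhibition, as the step from compound 1 to compound 4 a 2.3-fold higher number from compound 1 to compound 4 (0.37 log units; beyond the scatter). Compound 4 is therefore estimated at 45 nM in this assay, within a range from 15 nM to 150 nM.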

Compound 4, inhibition constant: 1540 nM
Compound 4: middle estimate off by 34-fold (1.53 log units), on the low side; the whole stated range lies below it.
By their numbers in this assay, from the lowest: compound 2; then compound 1; then compound 3; then compound 4.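

In this assay, among these compounds, replacing cyclopropyl with (dimethylamino)methyl on a saturated chain carbon bound to a nitrogen on an aromatic ring gives an 80-fold higher number from compound 1 to compound 4 (1.90 log units; beyond the scatter), the first single-place step. Among the compounds shown here, it shows that the number at this position depends strongly on the group carried there, which the earlier compounds, differing in several places at once, could not show. The change removes a ring of carbon only and brings in a nitrogen with one hydrogen-bond acceptor, and nothing available explains the size of the step.

The compounds shown do not separate the loss of the ring from the entry of the nitrogen, which an open carbon chain such as butyl could address. Also open, on these data alone, is whether an ether such as 2-methoxyethyl or a cyclic amine such as 2-(pyrrolidin-1-yl)ethyl would read closer to compound 1 or to compound 4.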